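The source may report more compounds than this note shows. Statements on the series, on what has been measured and on what is new or still open speak of the compounds shown alone.

Measured so far in a functional assay on MCF7 cells (Homo sapiens) for antiproliferative activity, with a stated time of 72 h; a lower number here means a stronger inhibitor, a higher number a weaker inhibitor:
compound 1 `CCN(C)Cc1c(OC)cc(OC)c(C(=O)/C=C/c2ccccc2Cl)c1O` — 6800 nM
compound 2 `COc1cc(OC)c(C(=O)/C=C/c2ccccc2Cl)c(O)c1CN(C)CCCN(C)C` — 3200 nM

For the measured compounds named here, compound 1 holds the highest of the two numbers in this assay; the only measured step is a 2.1-fold lower number from compound 1 to compound 2 (0.33 log units; beyond the scatter). Compound 3 `COc1cc(OC)c(C(=O)/C=C/c2ccccc2Cl)c(O)c1CN(C)C` differs from compound 1 by hydrogen in place of methyl on a saturated chain carbon bound to an amine nitrogen. That one measured step concerns a different change at the amine and so bears only loosely on this one; nothing measured tests the present change directly. A step within the scatter is therefore expected, with a 1.1-fold lower number from compound 1 to compound 3 (0.05 log units; within the scatter). Compound 3 is estimated at 6000 nM, range 2500 nM to 14000 nM.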

Compound 3, half-maximal inhibitory concentration: 90 nM
Estimate against measurement, compound 3: 67-fold (1.82 log units) above; the whole stated range lies above it.
By their numbers in this assay, from the lowest: compound 3; then compound 2; then compound 1.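

At this position a single carbon on the amine carries most of the activity: ethyl to methyl gives a 76-fold lower number from compound 1 to compound 3 (1.88 log units; beyond the scatter) in this assay and so far outweighs the modest step seen earlier. Hydrogen in place of 2-(dimethylamino)ethyl gives a 36-fold lower number from compound 2 to compound 3 (1.55 log units; beyond the scatter) and leaves the (dimethylamino)methyl group of compound 3 with the lowest number of the series. No evidence on hand accounts for this sharp dependence on the amine substituent.

Still open, from the compounds shown here alone, is whether an amine bearing a single methyl, or a morpholine ring in place of dimethylamino, keeps this activity. Also open, going by these compounds, is whether a propyl group on the amine nitrogen behaves like ethyl.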